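Swapping the aryl group on a urea nitrogen

The source may report more compounds than this note shows. Statements on the series, on what has been measured and on what is new or still open speak of the compounds shown alone.

Measured so far:
- compound 1, `CC(C)c1cccc(C(C)C)c1NC(=O)NC(c1ccccc1)c1ccccc1`: 45 nM
- compound 2, `CC(C)c1cccc(C(C)C)c1NC(=O)NCC1(c2cccnc2)CCCC1`: 97 nM
- compound 3, `COc1ccccc1NC(=O)NCC1(c2ccccc2)CCCCC1`: 270 nM

All three compounds share a urea linker, and all were tested in an assay on microsomes from intestine for inhibition of acyl-CoA:cholesterol acyltransferase (Oryctolagus cuniculus); a lower number here means a stronger inhibitor, a higher number a weaker inhibitor. In this assay compound 1 gives 45 nM, compound 2 gives 97 nM and compound 3 gives 270 nM. Compound 3 therefore has the highest number of the three, meaning it is the weakest inhibitor here; its gaps to compound 2 and to compound 1 are both beyond the usual scatter, so the ordering is trustworthy.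

The next compound, compound 4, `O=C(NCC1(c2ccccc2)CCCCC1)Nc1ccc(Cl)c(Cl)c1`, keeps the whole skeleton of compound 3 and alters only one part: 3,4-dichlorophenyl in place of 2-methoxyphenyl on an amide-type nitrogen. Within the data shown here, no measured pair in this set differs by exactly this kind of swap, so there is nothing to lean on except the general spread of the values, which all lie within a fairly narrow band.

Compound 4 is expected to give 200 nM in this assay, within a range of 60 nM to 700 nM. That estimate amounts to a step of a 1.4-fold lower number from compound 3 to compound 4 (0.13 log units; within the scatter), a modest expected gain that may well sit within the scatter.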

Compound 4, half-maximal inhibitory concentration: 3800 nM
Compound 4: middle estimate off by 19-fold (1.28 log units), on the low side, outside the stated range (above it).
By their numbers in this assay, from the lowest: compound 1; then compound 2; then compound 3; then compound 4.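

In this assay, putting 3,4-dichlorophenyl in place of 2-methoxyphenyl on the amide-type nitrogen gives a 14-fold higher number from compound 3 to compound 4 (1.15 log units; beyond the scatter), with the rest of the molecule left unchanged. Among these compounds, this is the first comparison in the set that isolates this nitrogen's aryl group, and it shows that the group strongly affects the measured inhibition: the step is large and well beyond the scatter. The two groups have the same heavy-atom count and the same kind of aromatic ring, so those counts alone do not separate them, and no measurement shown here explains the loss of inhibition.

The swap removes the methoxy group and adds two chlorines in a single move, so the compounds shown cannot tell whether losing the first or gaining the second accounts for the step. A plain phenyl ring on the same nitrogen would help to separate those two parts, while a phenyl ring bearing a carboxylic acid or a dimethylamino group would test how far this position tolerates quite different substituents.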